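A Piperazine Returns to the Chain of Compound 2

The source may report more compounds than this note shows. Statements on the series, on what has been measured and on what is new or still open speak of the compounds shown alone.

In an ADME assay on microsomes from liver (Mus musculus) for metabolic stability, read by LC-MS, with a stated time of 10 min, tested at 0.5 uM (a higher number here means that more of the compound is left, a lower number that less of the compound is left), compound 2 `c1ccc2c(c1)CN[C@@H](CN(CCC1CCNCC1)[C@H]1CCCc3cccnc31)C2` is the lower of the two measured compounds at 32%, while compound 1 `c1ccc2c(c1)CN[C@@H](CN(CCCN1CCNCC1)[C@H]1CCCc3cccnc31)C2` gives 92%. The change to compound 3 `CC(C)N1CCN(CCCN(C[C@H]2Cc3ccccc3CN2)[C@H]2CCCc3cccnc32)CC1` is (4-isopropylpiperazin-1-yl)methyl in place of piperidin-4-yl on a saturated chain carbon, two bonds along the chain from an amine nitrogen, on a saturated chain carbon, two bonds along the chain from an amine nitrogen. Within the data shown here, the one measured step bearing on it, a number 60 percentage points lower from compound 1 to compound 2 (beyond the scatter), is large and replaces (piperazin-1-yl)methyl with piperidin-4-yl. Among the measured compounds shown here, the new change runs the opposite way, but no measured compound carries the isopropyl group. A large rise is therefore expected, a number 40 percentage points higher from compound 2 to compound 3 (beyond the scatter). For compound 3 the estimated value is 72%, within an expected range of 45% to 92%.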

Compound 3, percent of the compound remaining: 58%
The estimate for compound 3 lay 14 percentage points above the measured number; low and high end bracket the measured number.
By their numbers in this assay, from the lowest: compound 2; then compound 3; then compound 1.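

In this assay, the substituted piperazine at this position wins back only part of the ground, with a number 26 percentage points higher from compound 2 to compound 3 (beyond the scatter), a modest rise. Isopropyl in place of hydrogen on the ring amine nitrogen comes at a large price, with a number 34 percentage points lower from compound 1 to compound 3 (beyond the scatter), so the number answers to what that nitrogen carries and not only to which ring sits on the chain. Nothing measured here explains either step. On these data alone, whether a methyl or an acetyl on that nitrogen would stay closer to compound 1 remains open. So does whether a cyclopropyl would behave like the isopropyl.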